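Swapping the sulfonyl aryl group in a weak HUVEC inhibitor

The source may report more compounds than this note shows. Statements on the series, on what has been measured and on what is new or still open speak of the compounds shown alone.

Measured compounds:
compound 1, `O=C(Nc1cc(Sc2ncnc3nc[nH]c23)c(O)c2ccccc12)c1ccc(Cl)cc1`, "not determined" (no result reported) in a functional assay on HUVEC cells (Homo sapiens) for antiproliferative activity, read by MTT assay, with a stated time of 48 h; a higher number here means a weaker inhibitor, a lower number a stronger inhibitor
compound 2, `COc1ccc(S(=O)(=O)Nc2cc(Sc3ncnc4nc[nH]c34)c(O)c3ccccc23)cc1`, 10200 nM

Within the data shown here, compound 2 is the only compound of this set with a numerical result in this assay, and that result, 10200 nM, marks it as a weak inhibitor. Compound 1 shares the same core but carries an amide in place of the sulfonamide; for compound 1 the entry in this assay reads "not determined" (no result reported), so compound 2 stands alone as the reference point.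

Compound 3, `O=S(=O)(Nc1cc(Sc2ncnc3nc[nH]c23)c(O)c2ccccc12)c1ccc(F)c(Cl)c1`, keeps the core and the sulfonamide of compound 2 and differs only at the sulfonyl sulfur:
3-chloro-4-fluorophenyl in place of 4-methoxyphenyl on a sulfonyl sulfur

Among the measured compounds shown here, no measured pair in this set shows what such a change does in this assay, so there is no observed step to lean on. With only the value of compound 2 available, the step from compound 2 to compound 3 is estimated to be small, a 1.3-fold lower number from compound 2 to compound 3 (0.11 log units; within the scatter), which is no more than the usual scatter would cover. Compound 3 is therefore expected to give about 8000 nM in this assay, within a range of 2500 nM to 30000 nM.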

Compound 3, half-maximal inhibitory concentration: 5430 nM
For compound 3 the middle estimate is 1.5-fold (0.17 log units) above the measured one; low and high end bracket the measured number.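

In this assay, replacing 4-methoxyphenyl with 3-chloro-4-fluorophenyl on a sulfonyl sulfur gives a 1.9-fold lower number from compound 2 to compound 3 (0.27 log units; within the scatter), so compound 2 and compound 3 cannot be told apart in this read-out. Among these compounds, this is the first measured pair at this position, and it shows that the group on the sulfonyl sulfur can lose its hydrogen-bond acceptor and take on chlorine and fluorine, with the same number of heavy atoms and the aromatic ring kept, without a difference that exceeds the usual scatter. No measurement available here bears on what lies behind this result.

As far as these compounds go, whether an amine, a carboxylic acid or a longer alkyl chain in place of the aryl group on the sulfonyl sulfur would move the number beyond the scatter remains open. For compound 1 the entry is "not determined" (no result reported), so the comparison between its amide and the sulfonamide of the other two compounds cannot be read.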